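This account rests on a few compounds, and the source may have more. Where it says the series, first, only, none or still open, it means among the compounds named here.

Of the compounds shown here, two with a shared core have been tested in an ADME assay on NIH3T3 cells (Mus musculus) for cytotoxicity, read by MTT assay, with a stated time of 24 h; a higher number here means a weaker inhibitor, a lower number a stronger inhibitor. Compound 1 `Cc1nnc(SCC(=O)N/N=c2/scc(-c3ccc([N+](=O)[O-])cc3)n2-c2ccccc2)s1` gives 177 ug/mL in this assay, and compound 2 `Cc1nnc(SCC(=O)N/N=c2/scc(-c3ccc(Br)cc3)n2-c2ccccc2)s1` gives 55 ug/mL. The change between them, bromo in place of nitro on an aromatic carbon, produced a 3.2-fold lower number from compound 1 to compound 2 (0.51 log units; beyond the scatter), so compound 2 holds the lowest of the two numbers measured. Compound 3 `Cc1ccc(-c2cs/c(=N/NC(=O)CSc3nnc(C)s3)n2-c2ccccc2)cc1` differs from compound 2 by methyl in place of bromo on an aromatic carbon. Within the data shown here, no measured step concerns this exchange; the one known step involved a different group. For compound 3 the expected step in this assay is therefore a 1.2-fold higher number from compound 2 to compound 3 (0.07 log units; within the scatter), and its estimated value is 65 ug/mL, with a range from 25 ug/mL to 170 ug/mL.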

Compound 3, half-maximal inhibitory concentration: 373 ug/mL
Compound 3: the middle estimate sits 5.7-fold (0.76 log units) below what was measured, outside the stated range (above it).
By their numbers in this assay, from the lowest: compound 2; then compound 1; then compound 3.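

Bromo and methyl each count one heavy atom, yet in this assay methyl in place of bromo gives a 6.8-fold higher number from compound 2 to compound 3 (0.83 log units; beyond the scatter), so this position on the aromatic ring does not treat them alike. Methyl in place of nitro gives a 2.1-fold higher number from compound 1 to compound 3 (0.32 log units; beyond the scatter), which leaves the nitro compound between the two single-atom groups. Nothing available explains this order. Where chloro, an amine or a carboxylic acid would fall at this place stays open. So does whether the same order would hold on a different core.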